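The source may hold more compounds than are shown below. What is called first, only, known or untested is meant among the compounds shown, and "the series" means these compounds.

Measured compounds in a functional assay on T47D cells (Homo sapiens) for inhibition; a higher number here means a weaker inhibitor, a lower number a stronger inhibitor:
- compound 1 `Oc1ccccc1-c1cc(-c2ccccc2F)cc(-c2ccccc2O)n1`: > 50000 nM, a limit of the assay.
- compound 2 `Oc1ccc(-c2cc(-c3cccc(F)c3)cc(-c3ccccc3O)n2)cc1`: > 50000 nM, a limit of the assay.
- compound 3 `Oc1ccccc1-c1cc(-c2ccc(C(F)(F)F)cc2)cc(-c2ccccc2O)n1`: > 50000 nM, a limit of the assay.

Compound 3 stands at the limit of this assay, and every value shown sits there too (the limit of > 50000 nM in this assay, at which 3 of the 3 values shown sit). For the measured compounds named here, the one change between measured compounds, a step that the two limits leave unreadable from compound 1 to compound 3, runs from one limit to another and cannot be read; its size is unknown.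

Compound 4 `Oc1ccc(-c2cc(-c3ccc(C(F)(F)F)cc3)cc(-c3ccccc3O)n2)cc1` is the next step from compound 3: 4-hydroxyphenyl in place of 2-hydroxyphenyl on an aromatic carbon. Going by the values given here, no measured step bears directly on this change. Compound 2, which also carries a 4-hydroxyphenyl group, gives only a limit in this assay, and no pairing among the measured compounds isolates the hydroxyphenyl exchange on its own. With every value shown at the limit (the limit of > 50000 nM in this assay, at which 3 of the 3 values shown sit), the expectation for compound 4 is again a limit, and the step that the limit leaves unreadable from compound 3 to compound 4 is expected to be nothing readable beyond the scatter.

For compound 4 the estimate in this assay is 60000 nM, with a range from 20000 nM to 200000 nM, most likely reported only as a limit.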

Compound 4, half-maximal inhibitory concentration: > 50000 nM
Compound 4 ended at the assay's limit; the forecaster's own chance of this, stated with the estimate: 85%; the middle value does not contradict the limit.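

The steps from compound 3 to compound 4 and from compound 2 to compound 4 cannot be read in this assay, with both ends of each step being limits: the limit of > 50000 nM in this assay, at which 4 of the 4 values shown sit.

The compounds shown leave open whether any of these group exchanges on the shared core alters inhibition at all.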